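The compounds below may be only part of what the source reports. "The series", "measured", "known", "first", "only" and "open" are said of these compounds alone.

Measured compounds:
compound 1 `CS(=O)(=O)c1ccc(-c2cnc3[nH]cc(-c4nnc(-c5ccc(F)cc5)o4)c(=O)c3c2)cc1` — 18.7%
compound 2 `CS(=O)(=O)c1ccc(-c2cnc3[nH]cc(-c4nnc(-c5ccccn5)o4)c(=O)c3c2)cc1` — 16.2%
compound 3 `CS(=O)(=O)c1ccc(-c2cnc3[nH]cc(-c4nnc(-c5ccc(Cl)cc5)o4)c(=O)c3c2)cc1` — 17%

In a functional assay on HCT-116 cells (Homo sapiens) for inhibition, read by MTT assay, with a stated time of 24 h, tested at 10 uM (on this read-out higher numbers stand for more inhibition of growth at the one concentration tested and lower numbers for less inhibition of growth), compound 3 gives 17%. Among the three numbers compound 3 stands second highest, but both gaps to its neighbours are within the scatter: a number 1.7 percentage points lower from compound 1 to compound 3 (within the scatter) and a number 0.8 percentage points higher from compound 2 to compound 3 (within the scatter). The whole series therefore sits on one level at the single concentration tested.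

Compound 4 `Cc1ccc(-c2nnc(-c3c[nH]c4ncc(-c5ccc(S(C)(=O)=O)cc5)cc4c3=O)o2)cc1` is the next member. The change from compound 3 is methyl in place of chloro on an aromatic carbon. The closest measured analogue of this change is the swap of one halogen for another on the same aromatic carbon, a number 1.7 percentage points lower from compound 1 to compound 3 (within the scatter), which was within the scatter; replacing the whole aryl ring by pyridin-2-yl, a number 2.5 percentage points lower from compound 1 to compound 2 (within the scatter), was likewise within the scatter. Within the data shown here, no measured step here has moved the read-out beyond the scatter, so for compound 4 the expected step is no change at the digits printed from compound 3 to compound 4 (within the scatter). Compound 4 is thus estimated at 17%, with a range of 8% to 27%.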

Compound 4, percent growth inhibition at one concentration: 24.4%
Compound 4: the middle estimate sits 7.4 percentage points below what was measured; the range from low to high includes it.
By their numbers in this assay, from the lowest: compounds 2, 3, 1 and 4 (each within the scatter of the next).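

Among these compounds, at this position, para to a large group, methyl is the first carbon substituent to replace a halogen, and in this assay it gives a number 7.4 percentage points higher from compound 3 to compound 4 (within the scatter). The comparisons with the other two members are a number 5.7 percentage points higher from compound 1 to compound 4 (within the scatter) and a number 8.2 percentage points higher from compound 2 to compound 4 (within the scatter), so steps of this size also stay inside the scatter, and 4-methylphenyl stands on one level with 4-fluorophenyl, 4-chlorophenyl and pyridin-2-yl. No supporting measurement bears on this result.

Still open, on these data alone, is whether any group on this aromatic carbon, such as a methoxy group, an amine, a carboxylic acid or a longer chain, would move the read-out beyond the scatter. A single concentration also leaves open how these compounds would compare across a range of concentrations.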